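The source may report more compounds than this note shows. Statements on the series, on what has been measured and on what is new or still open speak of the compounds shown alone.

Measured so far in the series:

Compound 1, `CC(C)(C)[Si](C)(C)OCC1OC(n2ccc(N)nc2=O)C(O[Si](C)(C)C(C)(C)C)C1C#N`: 8 ug/mL
Compound 2, `N#C[C@@H]1[C@@H](O)[C@H](n2ccc(=O)[nH]c2=O)O[C@@H]1CO`: 400 ug/mL

Among the measured compounds shown here, in a functional assay on cells (Fibroblast, Mus musculus) for cytotoxicity (on this read-out higher numbers stand for lower toxicity in this test and lower numbers for higher toxicity in this test), compound 2 gives 400 ug/mL and stands at the top of the two numbers recorded; the only other measured member, compound 1, sits well below it, a gap beyond the usual scatter. For the measured compounds named here, compound 1 also carries two silyl protecting groups and a different base, so the pair gives no isolated step to lean on.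

Compound 3, `N#C[C@H]1[C@@H](O)[C@H](n2ccc(=O)[nH]c2=O)O[C@@H]1CO`, is not yet measured in this assay. Relative to compound 2 the change is the two compounds have the same atoms and bonds and differ only in configuration as drawn: 1 of 4 stereo elements differ; a stereocentre at a saturated ring carbon is drawn R in compound 2 and S in compound 3. Going by the values given here, with no measured step available for such a change, the expectation in this assay is for a step of at most modest size, with no clear direction, and quite possibly none beyond the scatter. The step of a 1.3-fold lower number from compound 2 to compound 3 (0.12 log units; within the scatter) is therefore expected to be small. For compound 3 the estimated value is 300 ug/mL, with a range from 100 ug/mL to 800 ug/mL.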

Compound 3, minimum cytotoxic concentration: > 200 ug/mL
Compound 3: no number, only a limit; the forecaster's own chance of this, stated with the estimate: 20%; the middle value does not contradict the limit.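

Compound 3 gives > 200 ug/mL in this assay, which is a limit and not a number. The step from compound 2 to compound 3 therefore cannot be read. Still open, going by these compounds, is whether the change of configuration at the saturated ring carbon shifts this read-out at all, and in which direction.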